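From 2-Carboxyethenyl to 2-(Methylcarbamoyl)ethyl

The compounds below may be only part of what the source reports. "The series", "measured", "known", "first", "only" and "open" are said of these compounds alone.

In a functional assay on MCF7 cells (Homo sapiens) for inhibition, read by sulforhodamine B assay, with a stated time of 72 h (on this read-out higher numbers stand for weaker inhibition of growth and lower numbers for stronger inhibition of growth), compound 1 (`CCOC(=O)/C=C/c1ccncc1-c1ccc2ccccc2c1`) gives 8320 nM. Compound 2 (`O=C(O)/C=C/c1ccncc1-c1ccc2ccccc2c1`) gives > 10000 nM, which is a limit of the assay and not a number. Compound 3 (`CNC(=O)CCc1ccncc1-c1ccc2ccccc2c1`) carries 2-(methylcarbamoyl)ethyl in place of 2-carboxyethenyl on an aromatic carbon, opposite the ring nitrogen (2-(methylcarbamoyl)ethyl in place of 2-carboxyethenyl on an aromatic carbon). Among the compounds with values here, the one measured step bearing on this is an at least 1.2-fold higher number from compound 1 to compound 2 (0.07 log units; that floor lies within the scatter). It offers no size beyond the scatter, so no clear change in either direction is expected in this assay. The expected step is a number no higher from compound 2 to compound 3 (the limit leaves the size open). For compound 3 the estimated value is 10000 nM, with an expected range of 4000 nM to 25000 nM.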

Compound 3, concentration for 50% growth inhibition: > 10000 nM
Compound 3 was reported as a limit; the forecaster's own chance of this, stated with the estimate: 60%; the middle value lies on the limit itself.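

In this assay compound 3 gives > 10000 nM, which is a limit of the assay and not a number. With 2-(methylcarbamoyl)ethyl at this position, the step reads as an at least 1.2-fold higher number from compound 1 to compound 3 (0.07 log units; that floor lies within the scatter), so it shows no change beyond the scatter. The step between compound 2 and compound 3 cannot be read, and a second group on this aromatic carbon now ends at the same ceiling: the limit of > 10000 nM in this assay, at which 2 of the 3 values shown sit.

From the compounds shown here alone, how far compound 2 and compound 3 actually differ remains open. So does whether an amine or a longer chain here would give a readable number.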